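Methyl addition on the methoxypyridine ring of compound 2

The compounds below may be only part of what the source reports. "The series", "measured", "known", "first", "only" and "open" are said of these compounds alone.

Going by the values given here, compound 1 `C[C@H](NC(=O)c1cc(C(F)(F)F)nn1C)c1nc(-c2ccccn2)no1` is one of two compounds measured in an assay on T-REx-293 cells for inhibition of potassium channel subfamily T member 1 (Homo sapiens), read by patch clamp; on this read-out higher numbers stand for weaker inhibition and lower numbers for stronger inhibition. For compound 1 this assay reports only a limit, > 30000 nM. Among the compounds with values here, compound 2 `COc1cc(-c2noc([C@H](C)NC(=O)c3cc(C(F)(F)F)nn3C)n2)ccn1` gives 27 nM in this assay, and this is the only number so far. The other value, that of compound 1, is a limit, (the limit of > 30000 nM in this assay, at which 1 of the 2 values shown sits). Within the data shown here, the single measured step, an at least 1100-fold lower number from compound 1 to compound 2 (3.04 log units; beyond the scatter), exchanges one whole ring for another.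

Compound 3 `COc1cc(-c2noc([C@H](C)NC(=O)c3cc(C(F)(F)F)nn3C)n2)cc(C)n1` differs from compound 2 by methyl in place of hydrogen on an aromatic carbon. Among the measured compounds shown here, no measured step bears directly on this change: the only step available, an at least 1100-fold lower number from compound 1 to compound 2 (3.04 log units; beyond the scatter), concerned the identity of the ring itself rather than a methyl placed on it, so it offers no scale for the present change. With only a methyl entering, next to the ring nitrogen and meta to the methoxy group, no step beyond the scatter is expected in this assay in either direction. Compound 3 is therefore estimated at 30 nM, with a range from 8 nM to 120 nM. The expected step of a 1.1-fold higher number from compound 2 to compound 3 (0.05 log units; within the scatter) lies within the scatter.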

Compound 3, half-maximal inhibitory concentration: 505 nM
For compound 3 the middle estimate is 17-fold (1.23 log units) below the measured one, and the stated range ends below it.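

In this assay, going by these compounds alone, this position, on an aromatic carbon next to the ring nitrogen and meta to a methoxy group, proves sensitive to even the smallest substitution: methyl in place of hydrogen gives a 19-fold higher number from compound 2 to compound 3 (1.27 log units; beyond the scatter), the only step that changes a substituent on the ring rather than the identity of the ring. The 2-methoxy-6-methylpyridin-4-yl group nevertheless stays well apart from pyridin-2-yl, with an at least 59-fold lower number from compound 1 to compound 3 (1.77 log units; beyond the scatter), so the methyl reduces the inhibition seen with 2-methoxypyridin-4-yl without removing it. The value of compound 1, > 30000 nM, is a limit.

Nothing available gives a reason for the effect of this methyl. Going by these compounds, it remains open whether the higher number is specific to methyl or would also follow from a fluorine, a chlorine, an ethyl or an amine at the same carbon, and whether a methyl elsewhere on the 2-methoxypyridin-4-yl ring would give a step of similar size.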